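The compounds below may be only part of what the source reports. "The series", "measured", "known", "first", "only" and "open" are said of these compounds alone.

Of the compounds shown here, three built on a shared core have been tested in a functional assay on HCT-116 cells (Homo sapiens) for antiproliferative activity, read by WST assay, with a stated time of 72 h; a lower number here means a stronger inhibitor of growth, a higher number a weaker inhibitor of growth. Compound 1 (`N#Cc1ccc(CN[C@H]2[C@@H]3CN(c4ncc(C(=O)NO)cn4)C[C@@H]32)cc1`) gives 270 nM, and compound 3 (`O=C(NO)c1cnc(N2C[C@@H]3[C@H](C2)[C@H]3NCc2ccccc2)nc1`) gives 120 nM. Compound 2 (`O=C(NO)c1cnc(N2C[C@@H]3[C@H](C2)[C@H]3NS(=O)(=O)c2cccs2)nc1`) reads > 10000 nM, which is a limit of the assay and not a number. Compound 3 therefore holds the lower of the two true numbers, with compound 1 its nearest neighbour.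

The next candidate is compound 4 (`O=C(NO)c1cnc(N2C[C@@H]3[C@H](C2)[C@H]3NCC2CCCCC2)nc1`), and the change is cyclohexyl in place of phenyl on a saturated chain carbon bound to an amine nitrogen. Among the compounds with values here, two measured steps bear on it. The first is a 2.3-fold lower number from compound 1 to compound 3 (0.35 log units; beyond the scatter), a modest step made by hydrogen in place of cyano on an aromatic carbon of that same benzyl group. The second is an at least 83-fold lower number from compound 2 to compound 3 (1.92 log units; beyond the scatter), a large step made by benzyl in place of (thiophen-2-yl)sulfonyl on the amine nitrogen. Neither step swaps an aromatic ring for a non-aromatic one, so both offer only indirect guidance. The benzyl and cyclohexylmethyl groups match in heavy atoms, so a modest step in this assay seems likelier than a large one, and it is expected to lead to a somewhat higher number, estimated as a 1.7-fold higher number from compound 3 to compound 4 (0.22 log units; within the scatter). Compound 4 is expected at about 200 nM, with an estimated range of 70 nM to 600 nM.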

Compound 4, concentration for 50% growth inhibition: 160 nM
Beside the measured number, compound 4's estimate is 1.3-fold (0.10 log units) above it, and the stated range covers the measured number.
By their numbers in this assay, from the lowest: compounds 3, 4 and 1 (each within the scatter of the next, the first and the last beyond it). At a limit, above all of these: compound 2.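

In this assay, an aromatic ring turns out not to be required on the saturated chain carbon bound to an amine nitrogen: cyclohexyl in place of phenyl keeps the result within the scatter, a 1.3-fold higher number from compound 3 to compound 4 (0.12 log units; within the scatter). The cyclohexyl compound also stays within the scatter of the 4-cyanophenyl compound, a 1.7-fold lower number from compound 1 to compound 4 (0.23 log units; within the scatter), so compound 4 sits within reach of both benzyl-type compounds, even though those two lie beyond the scatter of each other. The large gap to the (thiophen-2-yl)sulfonyl group also holds with a non-aromatic ring in the amine substituent, an at least 62-fold lower number from compound 2 to compound 4 (1.79 log units; beyond the scatter), but this step rests on compound 2's value, which is a limit of the assay and not a number: the limit of > 10000 nM in this assay, at which 1 of the 4 values shown sits.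

From the compounds shown here alone, whether a ring is needed at this place at all remains open, and an open-chain group such as n-hexyl would address that. Also open, going by these compounds, is how a ring carrying a basic amine, such as piperidin-4-yl, or a benzoyl group on the amine nitrogen would read in this assay.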